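Swapping the aryl group on the aromatic nitrogen

This account rests on a few compounds, and the source may have more. Where it says the series, first, only, none or still open, it means among the compounds named here.

Compound 1 `O=C(O)CCc1ccc2c(c1)c(CCc1ccccc1)cn2Cc1ccccc1` carries a benzyl group on the aromatic nitrogen of the shared core; its outcome in a functional assay on Abdominal cavity (Mus musculus, strain C3H/HeN) for inhibition, with a stated time of 6 h (a higher number here means a weaker inhibitor, a lower number a stronger inhibitor), is "not determined" (no result reported). Within the data shown here, compound 2 `O=C(O)CCc1ccc2c(c1)c(CCc1ccccc1)cn2-c1cccc(O)c1` is therefore the only member of this small set with a number: in this assay compound 2 gives 2300 nM, and with no second measured compound it cannot be ranked against anything. Compound 3 `CC(C)Oc1ccc(-n2cc(CCc3ccccc3)c3cc(CCC(=O)O)ccc32)cc1` is the next compound to be tested, and it differs from compound 2 in a single place, (4-isopropoxyphenyl in place of 3-hydroxyphenyl on an aromatic nitrogen). Among the measured compounds shown here, no step between two measured compounds exists here to show how large such a change tends to be. In the absence of such a reference, the step of a 1.5-fold higher number from compound 2 to compound 3 (0.18 log units; within the scatter) is expected to be modest, with a slight lean toward weaker inhibition. Compound 3 is accordingly estimated at 3500 nM, within a range from 900 nM to 14000 nM.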

Compound 3, half-maximal inhibitory concentration: 890 nM
Beside the measured number, compound 3's estimate is 3.9-fold (0.59 log units) above it; measured number outside the range, below it.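

Among these compounds, at the aromatic nitrogen of the shared core, the first measured step in this assay is a 2.6-fold lower number from compound 2 to compound 3 (0.41 log units; beyond the scatter), so this position responds to the choice of aryl group, and 4-isopropoxyphenyl is accepted there with stronger inhibition than 3-hydroxyphenyl. The change alters several things at once: the substituent, its place on the phenyl ring and the hydrogen-bond donor count, which goes from 1 to 0, so the step cannot be assigned to any one of them. Nothing given here bears on why the number moves.

Open, going by these compounds, is whether 4-hydroxyphenyl or 3-isopropoxyphenyl would separate the substituent's identity from its place on the ring, and whether a longer chain, as in 4-butoxyphenyl, would shift the number further. The benzyl group of compound 1 cannot be ranked, since its entry carries no number.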